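Trifluoromethyl for tert-butyl on a diaryl urea

The compounds below may be only part of what the source reports. "The series", "measured", "known", "first", "only" and "open" are said of these compounds alone.

Measured so far:
- Compound 1, `Cc1cccc(NC(=O)N[C@@H](C)c2ccccc2)c1`, gives 99% in an ADME assay on the whole organism with Oryza sativa as the target, tested at 0.1 uM; a higher number here means a weaker effect of the compound at the concentration tested, a lower number a stronger effect.
- Compound 2, `C[C@@H](NC(=O)Nc1ccc(C(C)(C)C)cc1)c1ccccc1`, gives 100%.
- Compound 3, `C[C@H](NC(=O)Nc1ccc(C(C)(C)C)cc1)c1ccccc1`, gives 100%.

Compound 3 stands level with compound 2, and the two together give the highest numbers of the three; compound 1 sits only a little lower, within the scatter. The step of no change at the digits printed from compound 2 to compound 3 (within the scatter) shows that flipping the configuration at the saturated chain carbon leaves the read-out unchanged, which fits (the fact that compounds 2 and 3 differ only in the configuration as drawn).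

Compound 4, `C[C@H](NC(=O)Nc1ccc(C(F)(F)F)cc1)c1ccccc1`, differs from compound 3 as follows: trifluoromethyl in place of tert-butyl on an aromatic carbon. Going by the values given here, no measured step swaps a group on the aromatic ring, so none bears directly on this change; the only measured step, from compound 2 to compound 3, concerns configuration alone. All three measured compounds sit near the top of the scale, and with nothing pointing the other way the expectation is for compound 4 to stay there, with a step of a number 3 percentage points lower from compound 3 to compound 4 (within the scatter) that is estimated to lie within the scatter. Compound 4 is therefore expected to give about 97%, likely between 85% and 100%.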

Compound 4, a percentage reported as activity, at one concentration (the size of the read-out at that concentration, not a potency): 94%
For compound 4 the middle estimate is 3 percentage points above the measured one; the range from low to high includes it.
By their numbers in this assay, from the lowest: compounds 4, 1, 2 and 3 (each within the scatter of the next).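

Going by these compounds alone, this is the first step that swaps a group on the aromatic ring rather than configuration alone, and it gives a number 6 percentage points lower from compound 3 to compound 4 (within the scatter) in this assay at the place para to a large group. At this position, then, the all-carbon tert-butyl and the fluorine-bearing trifluoromethyl cannot be told apart by this read-out at the concentration tested, and the numbers of all four compounds still sit near the top of the scale, which means a weak effect. What is known about these compounds offers no explanation for the size of this step.

The compounds shown leave open what an amine, a carboxylic acid or a longer chain would do at this place on the ring. They also leave open how trifluoromethyl would behave with the opposite configuration at the saturated chain carbon.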